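Swapping a Thiophene for an Alkyne on a Nucleotide Chain

This account rests on a few compounds, and the source may have more. Where it says the series, first, only, none or still open, it means among the compounds named here.

Among the compounds with values here, compound 2 `O=c1[nH]/c(=N\OCCCc2ccsc2)ccn1[C@@H]1O[C@H](COP(=O)(O)OP(=O)(O)OP(=O)(O)O)[C@@H](O)[C@H]1O` stands as the lowest of the two numbers measured so far in a functional assay on 1321-N1 cells for agonist activity at P2Y purinoceptor 4 (Homo sapiens), read by scintillation counting and inositol phosphate accumulation (on this read-out higher numbers stand for an effect only at larger amounts of compound and lower numbers for an effect already at smaller amounts), where compound 2 gives 20 nM. Within the data shown here, its only measured neighbour, compound 1 `O=c1[nH]/c(=N\OCCCc2ccc(Br)cc2)ccn1[C@@H]1O[C@H](COP(=O)(O)OP(=O)(O)OP(=O)(O)O)[C@@H](O)[C@H]1O`, carries 4-bromophenyl on the same saturated chain carbon, three bonds along the chain from an oxygen, and in this assay compound 1 gives 141 nM; the step of a 7.1-fold lower number from compound 1 to compound 2 (0.85 log units; beyond the scatter) shows that exchanging the group at this place moves the read-out well beyond the scatter. Compound 3 `C#CCCCO/N=c1/ccn([C@@H]2O[C@H](COP(=O)(O)OP(=O)(O)OP(=O)(O)O)[C@@H](O)[C@H]2O)c(=O)[nH]1` takes the exchange one stage further: ethynyl in place of thiophen-3-yl on a saturated chain carbon, three bonds along the chain from an oxygen, so the five-membered aromatic ring gives way to a short group with no ring at all. Among the measured compounds shown here, no measured step covers the loss of a ring at this place; the one step that bears on it, a 7.1-fold lower number from compound 1 to compound 2 (0.85 log units; beyond the scatter), only shows that the group at this place can shift the number a great deal. With the ring removed, compound 3 is expected to act only at larger amounts, an estimated step of a 7.5-fold higher number from compound 2 to compound 3 (0.88 log units; beyond the scatter). Compound 3 is therefore estimated at 150 nM, within a range from 40 nM to 600 nM.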

Compound 3, half-maximal effective concentration: 410 nM
Beside the measured number, compound 3's estimate is 2.7-fold (0.44 log units) below it, within the range that was stated.
By their numbers in this assay, from the lowest: compound 2; then compound 1; then compound 3.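

In this assay, the new result shows that a ring at the end of this chain is not needed for activity, but that the ethynyl end carries a clear cost: a 21-fold higher number from compound 2 to compound 3 (1.31 log units; beyond the scatter), a step rated large where the step between the two ring-bearing compounds was rated modest. The ethynyl end also falls short of the 4-bromophenyl end, with a 2.9-fold higher number from compound 1 to compound 3 (0.46 log units; beyond the scatter), so among these three compounds both ring-bearing ends act at smaller amounts than the end without a ring, with thiophen-3-yl giving the lowest number. No measurement here explains why the read-out moves this way at this place.

This change removes the ring and also goes from 5 heavy atoms to 2, so the compounds shown cannot tell which of the two matters, and a cyclopropyl group or a plain pentyl chain at this place would be needed to pull them apart. On these data alone, it also remains open whether a longer chain ending in ethynyl, or an unsubstituted phenyl ring, would bring the number closer to that of compound 2.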